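This account rests on a few compounds, and the source may have more. Where it says the series, first, only, none or still open, it means among the compounds named here.

In a functional assay on KB cells (Homo sapiens) for cytotoxicity, read by MTT assay, with a stated time of 48 h (a higher number here means a weaker inhibitor, a lower number a stronger inhibitor), compound 1 (`CCn1cc(-c2nc3ccccc3[nH]2)c(=O)c2cc(F)c(N3CCNC(C)C3)c(F)c21`) gives 19100 nM, which lies within the scatter of compound 2 (`CCn1cc(-c2nc3ccccc3o2)c(=O)c2cc(F)c(N3CCNC(C)C3)c(F)c21`) at 18900 nM and of compound 3 (`CCn1cc(-c2nc3ccccc3s2)c(=O)c2cc(F)c(N3CCNC(C)C3)c(F)c21`) at 24300 nM. Compound 4 (`CCn1cc(-c2nc3ccc([N+](=O)[O-])cc3[nH]2)c(=O)c2cc(F)c(N3CCNC(C)C3)c(F)c21`) differs from compound 1 by one change: nitro in place of hydrogen on an aromatic carbon. The nearest measured steps replace the 1H-benzimidazol-2-yl group itself, and both a 1.0-fold lower number from compound 1 to compound 2 (0.00 log units; within the scatter) and a 1.3-fold higher number from compound 1 to compound 3 (0.10 log units; within the scatter) stay within the scatter. Among the measured compounds shown here, neither adds a substituent, so they offer only indirect guidance, and the data hold no direct precedent for nitro. Only a small move towards a lower number is therefore expected, without a clear step beyond the scatter. The estimated change is a 1.4-fold lower number from compound 1 to compound 4 (0.13 log units; within the scatter). For compound 4, the estimated value is 14000 nM, with an expected range of 5000 nM to 30000 nM.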

Compound 4, half-maximal inhibitory concentration: 2300 nM
Compound 4: the middle estimate sits 6.1-fold (0.78 log units) above what was measured; measured number outside the range, below it.
By their numbers in this assay, from the lowest: compound 4; then compounds 2, 1 and 3 (each within the scatter of the next).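

In this assay, nitro in place of hydrogen on the six-membered aromatic ring of carbon only, in the fused system of two rings, gives an 8.3-fold lower number from compound 1 to compound 4 (0.92 log units; beyond the scatter), so this place responds to a substituent. Exchanging the whole 1H-benzimidazol-2-yl group for 1,3-benzoxazol-2-yl or 1,3-benzothiazol-2-yl had shown no step beyond the scatter. Nothing available explains this step. From the compounds shown here alone, whether an amine, a carboxylic acid or a methoxy group here would give a similar step remains open. So does whether nitro would act likewise on the 1,3-benzoxazol-2-yl or 1,3-benzothiazol-2-yl compounds.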